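From compound 3 to its 2,3-dichlorophenyl analogue

The compounds below may be only part of what the source reports. "The series", "measured", "known", "first", "only" and "open" are said of these compounds alone.

In a functional assay on MCF7 cells (Homo sapiens) for antiproliferative activity, read by MTT assay, with a stated time of 72 h (a higher number here means a weaker inhibitor, a lower number a stronger inhibitor), compound 3 (`O=C(N/N=C/c1ccccc1)Nc1ccc(Oc2ccnc3[nH]ccc23)cc1`) gives 1510 nM as the reference point for this step. Compound 1 (`O=C(N/N=C/c1ccccc1)Nc1ccc(Oc2ccnc3[nH]ccc23)c(F)c1`) gives 2380 nM, which lies within the scatter of compound 3. Compound 2 (`O=C(N/N=C/c1ccc([N+](=O)[O-])cc1)Nc1ccc(Oc2ccnc3[nH]ccc23)c(F)c1`) gives 4000 nM, a higher number and beyond the scatter of compound 3.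

The unmeasured compound 4 (`O=C(N/N=C/c1cccc(Cl)c1Cl)Nc1ccc(Oc2ccnc3[nH]ccc23)cc1`) keeps the core of compound 3 and carries 2,3-dichlorophenyl in place of phenyl on a carbon with a double bond to nitrogen.

The nearest evidence is the nitro change on the phenyl that is replaced here: a 1.7-fold higher number from compound 1 to compound 2 (0.23 log units; within the scatter) was measured with fluoro still on the core. The other step, a 1.6-fold lower number from compound 1 to compound 3 (0.20 log units; within the scatter), is hydrogen in place of fluoro at a different place and gives no direct guide. Within the data shown here, no chlorine-bearing compound has been measured, so the evidence for this change is thin. Compound 2 still offers a reason for a slight lean towards a higher number, with no shift beyond the scatter expected. The estimate amounts to a 1.3-fold higher number from compound 3 to compound 4 (0.12 log units; within the scatter) as the expected step. Compound 4 is estimated at 2000 nM in this assay, with an expected range from 800 nM to 5000 nM for a measured value.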

Compound 4, half-maximal inhibitory concentration: "not active" (no number reported)
No number was reported for compound 4, and the estimate cannot be compared.
By their numbers in this assay, from the lowest: compounds 3, 1 and 2 (each within the scatter of the next, the first and the last beyond it).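

In this assay, among these compounds, compound 4 is recorded as "not active" with no number, so no step from compound 3 to compound 4 can be read. No measured evidence bears on this result.

The compounds shown leave open how 2,3-dichlorophenyl in place of phenyl shifts the number, and whether compound 4's result is specific to that group.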